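A few compounds are considered here, and "the series" means these few. Any claim that something is new, unique, unknown or untested is made for them only; others in the source may bear on it.

Measured in a functional assay on DU-145 cells (Homo sapiens) for cytotoxicity, in the presence of a further agent that is not named here; on this read-out lower numbers stand for stronger inhibition and higher numbers for weaker inhibition:
- Compound 1 `Clc1ccc(-c2cc(-c3ccsc3)nc(-c3ccccc3Cl)c2)o1`: 19300 nM
- Compound 2 `Clc1ccc(-c2cc(-c3ccc(Cl)o3)cc(-c3ccsc3)n2)cc1`: 19500 nM
- Compound 3 `Clc1ccc(-c2cc(-c3ccoc3)cc(-c3ccsc3)n2)cc1`: 37600 nM

Compound 2 cannot be separated from either of the other two compounds. Swapping in 4-chlorophenyl for 2-chlorophenyl gives a 1.0-fold higher number from compound 1 to compound 2 (0.00 log units; within the scatter), and swapping in furan-3-yl for 5-chlorofuran-2-yl gives a 1.9-fold higher number from compound 2 to compound 3 (0.29 log units; within the scatter). Both steps bear on the next compound, and neither goes beyond the scatter. Compound 4 `Cc1ccc(-c2cc(-c3ccc(Cl)o3)cc(-c3ccsc3)n2)cc1` has methyl in place of chloro on an aromatic carbon, para to a large group (methyl in place of chloro on an aromatic carbon). Going by the values given here, no measured step tests this exact swap, so only a small change is expected, with a 1.1-fold higher number from compound 2 to compound 4 (0.05 log units; within the scatter) estimated to stay within the scatter. The estimated value for compound 4 is 22000 nM, with an expected range of 11000 nM to 45000 nM.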

Compound 4, half-maximal inhibitory concentration: 21200 nM
For compound 4 the middle estimate is 1.0-fold (0.02 log units) above the measured one; the range from low to high includes it.
By their numbers in this assay, from the lowest: compounds 1, 2, 4 and 3 (each within the scatter of the next).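

In this assay, methyl in place of chloro on this aromatic carbon gives a 1.1-fold higher number from compound 2 to compound 4 (0.04 log units; within the scatter), so the read-out does not tell these two groups apart at this position. 4-Methylphenyl in place of 2-chlorophenyl likewise gives a 1.1-fold higher number from compound 1 to compound 4 (0.04 log units; within the scatter), which adds a second comparison without a readable change. No other measurement bears on why these compounds read alike. From the compounds shown here alone, whether an amine or a carboxylic acid on this aromatic carbon would move the number beyond the scatter remains open.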